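The compounds below may be only part of what the source reports. "The series", "measured", "known", "first", "only" and "open" are said of these compounds alone.

Measured so far:
Compound 1 `CC(C)(C)NCc1c(C(=O)O)nn(-c2ccccc2)c1-c1ccc(F)cc1`: > 680000 nM (a limit, not a number)
Compound 2 `CC(C)(C)NCc1c(C(=O)O)nn(-c2ccccc2)c1-c1ccc(Cl)cc1`: 145000 nM

Among the measured compounds shown here, in a functional assay on PC-3 cells (Homo sapiens) for inhibition, read by sulforhodamine B assay, with a stated time of 48 h (a lower number here means a stronger inhibitor of growth, a higher number a weaker inhibitor of growth), compound 2 gives 145000 nM, the only true number in this small set. Compound 1 gives > 680000 nM, which is a limit of the assay.

The next compound to consider is compound 3 `CC(C)(C)NCc1c(C(=O)O)nn(-c2ccccc2)c1-c1ccc(Br)cc1`. It keeps the core of compound 2 and changes one group, bromo in place of chloro on an aromatic carbon.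

For the measured compounds named here, one measured step bears on this change. Chloro in place of fluoro at that same aromatic carbon gave an at least 4.6-fold lower number from compound 1 to compound 2 (0.67 log units; beyond the scatter), which lies beyond the scatter. That single step points towards a lower number as the halogen changes again, although one step is thin support for a trend. A smaller move than that one seems the cautious expectation.

In this assay, the expected change is a 1.5-fold lower number from compound 2 to compound 3 (0.16 log units; within the scatter), and it may not clear the scatter. The estimate for compound 3 is 100000 nM, with an expected range of 45000 nM to 250000 nM.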

Compound 3, concentration for 50% growth inhibition: > 585000 nM
Compound 3 ended at the assay's limit (the forecaster's own chance of this, stated with the estimate: 10%); middle value at least 5.8-fold (0.76 log units) away from the limit.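

In this assay, the fall in the number seen on going from fluoro to chloro does not carry on to the next halogen at this same aromatic carbon: moving from 4-chlorophenyl to 4-bromophenyl gives an at least 4.0-fold higher number from compound 2 to compound 3 (0.60 log units; beyond the scatter), so the series of halogens shows no steady trend in one direction. The result for compound 3 is a limit of the assay and not a true number: the limit of > 585000 nM in this assay, at which 1 of the 3 values shown sits. Compound 1 also stands at a limit, so the step between compound 1 and compound 3 cannot be read, and of the three halogens shown only chloro, in compound 2, gives a true number.

The compounds shown leave open what true values lie behind the two limits, and so whether fluoro and bromo differ from each other at all. They also leave open how a methyl or a methoxy group on this same aromatic carbon would compare with chloro, which would show whether this change depends on halogens alone.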